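The compounds below may be only part of what the source reports. "The series", "measured", "known", "first", "only" and "open" are said of these compounds alone.

Compound 3, `CCCCCCCCCCCCc1ccc(C(=O)/C=C/C(=O)O)cc1`, gives 5820 nM in a functional assay on HeLa cells (Homo sapiens) for inhibition, read by MTT assay, with a stated time of 72 h; on this read-out lower numbers stand for stronger inhibition and higher numbers for weaker inhibition. Among the three compounds measured there it holds the second highest number; compound 1, `CC(C)(C)c1ccc(C(=O)/C=C/C(=O)O)cc1`, gives 5100 nM in this assay and sits within the scatter of compound 3, while compound 2, `O=C(O)/C=C/C(=O)c1ccc(Br)cc1`, gives 18700 nM in this assay and stands apart from compound 3 beyond the scatter.

Compound 4, `CCCCc1ccc(C(=O)/C=C/C(=O)O)cc1`, has not yet been measured. It differs from compound 3 by hydrogen in place of octyl on a saturated chain carbon, four bonds along the chain from an aromatic carbon.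

For the measured compounds named here, only one step has been measured, a 3.7-fold higher number from compound 1 to compound 2 (0.56 log units; beyond the scatter), and it concerns an aromatic substituent rather than the length of a chain, so it gives little guidance. What bears more directly is that compound 1 and compound 3, which differ widely in the size of the group on the aromatic ring, give numbers within the scatter of each other in this assay. Shortening the chain is therefore expected to change little, and compound 4 is estimated at 6000 nM, between 2500 nM and 15000 nM, a step of a 1.0-fold higher number from compound 3 to compound 4 (0.01 log units; within the scatter) expected to stay within the scatter.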

Compound 4, half-maximal inhibitory concentration: 4780 nM
For compound 4 the middle estimate is 1.3-fold (0.10 log units) above the measured one, within the range that was stated.
By their numbers in this assay, from the lowest: compounds 4, 1 and 3 (each within the scatter of the next); then compound 2.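

In this assay, hydrogen in place of octyl on a saturated chain carbon, four bonds along the chain from an aromatic carbon, gives a 1.2-fold lower number from compound 3 to compound 4 (0.09 log units; within the scatter) and so shows that this stretch of chain can be lost without a readable change. On the aromatic carbon, butyl in place of tert-butyl gives a 1.1-fold lower number from compound 1 to compound 4 (0.03 log units; within the scatter) so the straight and the branched group cannot be told apart there. Butyl in place of bromo gives a 3.9-fold lower number from compound 2 to compound 4 (0.59 log units; beyond the scatter) so a second group, besides tert-butyl, now stands apart from bromo on that carbon.

The compounds shown leave open whether an ethyl chain, or a butyl chain ending in an amine or a hydroxyl group, would stay level with compound 4. No measurement is offered here that would account for these numbers.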